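Substituent swap on the aryl ketone side of the series

The compounds below may be only part of what the source reports. "The series", "measured", "known", "first", "only" and "open" are said of these compounds alone.

Measured compounds in a functional assay on MCF7 cells (Homo sapiens) for antiproliferative activity, read by sulforhodamine B assay, with a stated time of 72 h, tested at 10 uM; on this read-out higher numbers stand for a weaker effect at the one concentration tested and lower numbers for a stronger effect:
compound 1 `COc1cc(Br)cc(/C=C/C(=O)c2ccccc2)c1O`: 67%
compound 2 `COc1cc(Br)cc(/C=C/C(=O)c2ccc(Cl)cc2)c1O`: 53.3%
compound 3 `COc1cc(Cl)cc(/C=C/C(=O)c2ccc(Br)cc2)c1O`: 38.2%

Compound 2 stands second highest of the three numbers. Within the data shown here, its nearest neighbour is compound 1, whose number is higher by the step of a number 13.7 percentage points lower from compound 1 to compound 2 (beyond the scatter), and that step, chloro in place of hydrogen on an aromatic carbon, is the only single-point comparison available. Compound 3 differs from compound 2 in two places, so of that pair only the two values can be set side by side: compound 3 gives the lowest number of the three.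

The next compound, compound 4 `COc1cc(Br)cc(/C=C/C(=O)c2ccc(C)cc2)c1O`, is not yet measured. It differs from compound 2 by methyl in place of chloro on an aromatic carbon, the place being on an aromatic carbon of a six-membered aromatic ring of carbon only, para to a large group. Among the measured compounds shown here, no measured step covers methyl in place of chloro. For the measured compounds named here, the one step at this position, from compound 1 to compound 2, was of modest size and went to a lower number when the chloro entered. Since compound 4 keeps a group at that place rather than returning to hydrogen, the expected step of a number 4.7 percentage points higher from compound 2 to compound 4 (within the scatter) is small, possibly slightly upward, and not clearly beyond the scatter. Compound 4 is therefore estimated at 58%, within 45% to 72%.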

Compound 4, a percentage reported as activity, at one concentration (the size of the read-out at that concentration, not a potency): 96.8%
Estimate against measurement, compound 4: 38.8 percentage points below, and the stated range ends below it.
By their numbers in this assay, from the lowest: compound 3; then compound 2; then compound 1; then compound 4.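

In this assay, a group at this place, on an aromatic carbon para to a large group, can move the number in either direction from the hydrogen of compound 1: a number 29.8 percentage points higher from compound 1 to compound 4 (beyond the scatter) runs opposite to a number 13.7 percentage points lower from compound 1 to compound 2 (beyond the scatter) and shows that filling the place does not by itself give a lower number. The exchange of one heavy atom for one heavy atom, with methyl in place of chloro, gives a number 43.5 percentage points higher from compound 2 to compound 4 (beyond the scatter) and is the largest single-place step in the series, so the identity of the group matters here and not only its presence. Nothing available accounts for why chloro and methyl part so widely.

On these data alone, with only hydrogen, chloro and methyl compared at this place, it remains open whether fluoro, methoxy, trifluoromethyl or an amine would side with chloro or with methyl. As far as these compounds go, compound 3 changes two places at once, so the contributions of its bromo and chloro groups cannot be separated, and it is also open whether the methyl step would carry over to a core with chloro in place of the bromo of compound 4.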